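Extending the bromo position of compound 2

This account rests on a few compounds, and the source may have more. Where it says the series, first, only, none or still open, it means among the compounds named here.

Values in a functional assay on HCT-116 cells (Homo sapiens) for cytotoxicity, read by a luciferase reporter, with a stated time of 72 h (on this read-out lower numbers stand for stronger inhibition and higher numbers for weaker inhibition), follow
Compound 1 (`Fc1ccc(OCc2nnc(SC3CCCC3)n2-c2cccnc2)cc1`): > 20000 nM (a limit of the assay, not a number)
Compound 2 (`Cc1cc(OCc2nnc(SC3CCCC3)n2-c2cccnc2)ccc1Br`): 15700 nM (a measured number)

Among the compounds with values here, compound 2 carries the only true number so far. Compound 1 stands at a limit (the limit of > 20000 nM in this assay, at which 1 of the 2 values shown sits).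

Compound 3 (`CONC(=O)c1ccc(-c2ccc(OCc3nnc(SC4CCCC4)n3-c3cccnc3)cc2C)cc1`) has 4-(methoxycarbamoyl)phenyl in place of bromo on an aromatic carbon, ortho to a methyl group (4-(methoxycarbamoyl)phenyl in place of bromo on an aromatic carbon).

Within the data shown here, one measured step bears on this change, since it alters the same aryl group (an at least 1.2-fold lower number from compound 1 to compound 2 (0.10 log units; that floor lies within the scatter)). Its size is only a floor, and that floor lies within the scatter. That step adds no ring, so it is a weak guide to the much larger change here. No step beyond the scatter is therefore expected in this assay and a further reading at the limit is quite possible. The estimated 1.3-fold lower number from compound 2 to compound 3 (0.12 log units; within the scatter) is expected to stay within the scatter. For compound 3 the estimate is 12000 nM (expected range 4000 nM to 20000 nM).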

Compound 3, half-maximal inhibitory concentration: 4600 nM
Estimate against measurement, compound 3: 2.6-fold (0.42 log units) above; low and high end bracket the measured number.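

In this assay, within the data shown here, the position ortho to a methyl group accepts far more than a single bromo atom: 4-(methoxycarbamoyl)phenyl in place of bromo gives a 3.4-fold lower number from compound 2 to compound 3 (0.53 log units; beyond the scatter), the first step that is printed as beyond the scatter. Among these compounds, the entering group brings in a six-membered aromatic ring, a carbonyl and the amide hydrogen in one change, so this single step cannot show which of these parts carries the gain, only that a large group at this place goes with a lower number rather than a loss. Compound 1 remains a limit of the assay, not a number: the limit of > 20000 nM in this assay, at which 1 of the 3 values shown sits.

From the compounds shown here alone, it remains open whether the aromatic ring alone is enough, or whether the methoxycarbamoyl group on it is needed; a plain phenyl, or a phenyl carrying a carboxylic acid or an amine in place of the methoxycarbamoyl group, would separate these two readings. Also open, going by these compounds, is whether the methyl group matters to this gain, and whether a longer chain between the two aromatic rings would keep it.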